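From Propargyl to (Furan-2-yl)methyl on a Shared Core

This account rests on a few compounds, and the source may have more. Where it says the series, first, only, none or still open, it means among the compounds named here.

Among the compounds with values here, in a functional assay on U-373MG ATCC cells for inhibition, with U373 MG (Homo sapiens) as the target, read by MTT assay, with a stated time of 7 days (on this read-out lower numbers stand for stronger inhibition of growth and higher numbers for weaker inhibition of growth), compound 1 `C#CCn1nnc2c(C(N)=O)ncn2c1=O` gives 37600 nM, the only actual number among the three compounds tested so far. Compound 2 `COc1cccc(Cn2nnc3c(C(N)=O)ncn3c2=O)c1` returns only a limit, > 50000 nM. Compound 3 `COc1ccc(Cn2nnc3c(C(N)=O)ncn3c2=O)cc1` also returns only a limit, > 50000 nM. The series therefore offers (the limit of > 50000 nM in this assay, at which 2 of the 3 values shown sit), and compound 1 has no measured neighbour against which a step could be sized.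

Compound 4 `NC(=O)c1ncn2c(=O)n(Cc3ccco3)nnc12` keeps the core of compound 1 and exchanges propargyl for (furan-2-yl)methyl, with furan-2-yl in place of ethynyl on a saturated chain carbon bound to an aromatic nitrogen.

Within the data shown here, with no measured step to serve as a guide, any forecast in this assay remains tentative. A small shift toward weaker growth inhibition seems most likely, and it may not clear the usual scatter. This direction rests on (the limit of > 50000 nM in this assay, at which 2 of the 3 values shown sit), which is shared by compound 2 and compound 3. A result reported only as a limit is also a real possibility for the new compound. The expected change is a 1.3-fold higher number from compound 1 to compound 4 (0.12 log units; within the scatter). For compound 4 the estimated value is 50000 nM, with an expected range of 28000 nM to 100000 nM.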

Compound 4, concentration for 50% growth inhibition: > 50000 nM
Compound 4: a limit, no number; the forecaster's own chance of this, stated with the estimate: 60%; the middle value sits exactly at the limit.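

In this assay, within the data shown here, replacing propargyl with (furan-2-yl)methyl on the shared core gives an at least 1.3-fold higher number from compound 1 to compound 4 (0.12 log units; that floor lies within the scatter), the first step that can be sized at all, though only as a floor. Compound 4 gives > 50000 nM, which is a limit of the assay and not a number. At this place, on a saturated chain carbon bound to an aromatic nitrogen, a furan-2-yl group therefore gives no measurable value, and compound 4 joins the compounds that reach the same limit: the limit of > 50000 nM in this assay, at which 3 of the 4 values shown sit.

Among these compounds, the true distance between compound 1 and compound 4 remains unknown, and compound 1 is still the only compound here with an actual number, so the series offers no measured value against which to compare it. Also open, on these data alone, is whether an amine or a carboxylic acid at this place, or a longer chain in place of propargyl, would give a number under the limit and whether that number would differ from that of compound 1 by more than the scatter.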